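Swapping Chloro for Trifluoromethyl on Compound 2

The source may hold more compounds than are shown below. What is called first, only, known or untested is meant among the compounds shown, and "the series" means these compounds.

Compound 1 `Fc1ccc(-c2nc3ccccn3c2NC2CCCCC2)cc1` and compound 2 `Clc1ccc(-c2nc3ccccn3c2NC2CCCCC2)cc1` share one core and differ only in the group that sits on the six-membered aromatic ring of carbon only. In an assay on membranes from brain for displacement of a labelled ligand from adenosine receptor A1 (Rattus norvegicus) (a lower number here means a stronger inhibitor, a higher number a weaker inhibitor), compound 1 gives > 100000 nM, which is a limit of the assay rather than a number. Compound 2 gives > 100000 nM in this assay, again a limit. Because both values sit at the limit of > 100000 nM in this assay, at which 2 of the 2 values shown sit, the step that the two limits leave unreadable from compound 1 to compound 2 cannot be read. Compound 2 therefore stands only at that limit, with no measured number of its own.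

Compound 3 `FC(F)(F)c1ccc(-c2nc3ccccn3c2NC2CCCCC2)cc1` carries trifluoromethyl in place of chloro on an aromatic carbon. Among the compounds with values here, the only measured step that bears on this change is a step that the two limits leave unreadable from compound 1 to compound 2, and its size is unreadable, so nothing measured points toward a gain or a loss. Compound 3 is therefore expected to remain near the limit. The estimate for compound 3 in this assay is 150000 nM, with a range from 30000 nM to 1000000 nM. The expected step that the limit leaves unreadable from compound 2 to compound 3 is thus no step beyond the scatter.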

Compound 3, inhibition constant: > 100000 nM
Compound 3: only a limit was reported; the forecaster's own chance of this, stated with the estimate: 85%; the middle value lies beyond the limit too.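

In this assay compound 3 gives > 100000 nM, which is a limit of the assay and not a number. Within the data shown here, no step among compound 1, compound 2 and compound 3 can therefore be read: the limit of > 100000 nM in this assay, at which 3 of the 3 values shown sit.

The compounds shown leave open how fluoro, chloro and trifluoromethyl rank against one another in this assay, and whether any group at this place on the shared core gives a measurable value.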